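An oxadiazole swap at the limit of the assay

The source may report more compounds than this note shows. Statements on the series, on what has been measured and on what is new or still open speak of the compounds shown alone.

Of the compounds shown here, three have been measured in a functional assay on MIA PaCa-2 cells (Homo sapiens) for inhibition, read by MTT assay, with a stated time of 3 days (on this read-out lower numbers stand for stronger inhibition and higher numbers for weaker inhibition), and none of them yields a number. Compound 1 (`CC(C)c1noc(N2CCN(C(=O)[C@@H]3CCCN(S(=O)(=O)c4ccc(S(=O)(=O)NC(C)(C)C)cc4)C3)CC2)n1`) reads > 10000 nM, which is a limit of the assay. Compound 2 (`CC(C)NS(=O)(=O)c1ccc(S(=O)(=O)N2CCC[C@@H](C(=O)N3CCN(c4nc(C(C)C)no4)CC3)C2)cc1`) reads > 10000 nM, again a limit. Compound 3 (`CCN(CC)S(=O)(=O)c1ccc(S(=O)(=O)N2CCC[C@@H](C(=O)N3CCN(c4nnc(C(C)C)o4)CC3)C2)cc1`) reads > 10000 nM, also a limit, so it offers no exact starting point. The whole set so far amounts to the limit of > 10000 nM in this assay, at which 3 of the 3 values shown sit.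

Compound 4 (`CCN(CC)S(=O)(=O)c1ccc(S(=O)(=O)N2CCC[C@@H](C(=O)N3CCN(c4nc(C(C)C)no4)CC3)C2)cc1`) has not yet been measured. It differs from compound 3 at one place, and the two have the same atoms, joined differently: 3-isopropyl-1,2,4-oxadiazol-5-yl in place of 5-isopropyl-1,3,4-oxadiazol-2-yl on an amine nitrogen in a ring. Going by the values given here, the one measured step is a step that the two limits leave unreadable from compound 1 to compound 2. That step concerns a different place in the molecule, so it gives no size to carry over. The entering group is already present in compound 1 and compound 2, and neither gives a number.

With compound 3 at > 10000 nM, a limit, no step beyond the usual scatter is expected in this assay. The expected step is a step that the limit leaves unreadable from compound 3 to compound 4. Compound 4 is estimated at 15000 nM, with an expected range from 6000 nM to 40000 nM, and it will most likely be reported only as a limit.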

Compound 4, half-maximal inhibitory concentration: > 10000 nM
Compound 4 gave a limit, no number (the forecaster's own chance of this, stated with the estimate: 90%); the middle value lies beyond the limit too.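

In this assay compound 4 reads > 10000 nM, which is a limit and not a number. The steps to compound 4 from compound 1, compound 2 and compound 3 cannot be read. The compounds shown leave open whether swapping the oxadiazole or the amino group on the sulfonyl sulfur changes inhibition at all, as the whole set sits at one reading: the limit of > 10000 nM in this assay, at which 4 of the 4 values shown sit.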